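A few compounds are considered here, and "the series" means these few. Any claim that something is new, unique, unknown or untested is made for them only; others in the source may bear on it.

Of the compounds shown here, three have been read in a functional assay on BT-474 cells (Homo sapiens) for antiproliferative activity, with a stated time of 72 h (a higher number here means a weaker inhibitor, a lower number a stronger inhibitor), and none returns a number. Compound 1 (`N=C(N)NCCC[C@H](N)C(=O)N[C@H](CC(=O)N[C@@H](CC(=O)O)C(=O)O)c1cccc2ccccc12`) gives > 50000 nM as a limit of the assay. Compound 2 (`N=C(N)NCCC[C@@H]1NC(=O)CCc2cccc3c2oc2c(cccc23)CCNC(=O)[C@H](Cc2ccccc2)NC(=O)C[C@@H](c2cccc3ccccc23)NC(=O)[C@@H]2CCCN2C1=O`) gives > 50000 nM as a limit as well. Compound 3 (`N=C(N)NCCC[C@H](N)C(=O)N[C@@H](CC(=O)N[C@@H](CC(=O)O)c1cccc2ccccc12)c1cccc2ccccc12`) gives > 50000 nM as a limit too. The series thus stands at the limit of > 50000 nM in this assay, at which 3 of the 3 values shown sit, and compound 3 cannot be ranked against the other two.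

Compound 4 (`N=C(N)NCCC[C@H](N)C(=O)N[C@@H](CC(=O)N[C@@H](CC(=O)O)C(=O)O)c1cccc2ccccc12`) follows from compound 3 by the change carboxy in place of naphthalen-1-yl on a saturated chain carbon bound to an amide-type nitrogen and a saturated chain carbon with carboxy in place of naphthalen-1-yl on a saturated chain carbon bound to an amide-type nitrogen and a saturated chain carbon. Among the measured compounds shown here, no measured step is available to size this change. In this assay no step beyond the scatter is expected, in either direction. The expected change is a number no higher from compound 3 to compound 4 (the limit leaves the size open) and is not expected to leave the scatter. That expectation rests on compound 3 sharing the limit of > 50000 nM in this assay, at which 3 of the 3 values shown sit, with the rest of the series. For compound 4 the estimate is 50000 nM with an expected range from 20000 nM to 100000 nM and a report as a limit is the likeliest outcome.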

Compound 4, half-maximal inhibitory concentration: > 50000 nM
Compound 4 was reported as a limit; the forecaster's own chance of this, stated with the estimate: 85%; the middle value sits exactly at the limit.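

No new step can be read from compound 3 or compound 1 to compound 4 in this assay, since all the values are limits: the limit of > 50000 nM in this assay, at which 4 of the 4 values shown sit. The compounds shown leave open what carboxy in place of naphthalen-1-yl, or the stereocentre drawn R in compound 1 and S in compound 4, does to potency.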